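A few compounds are considered here, and "the series" means these few. Any claim that something is new, unique, unknown or untested is made for them only; others in the source may bear on it.

Measured so far in a functional assay on Bel-7402 cells (Homo sapiens) for antiproliferative activity, read by MTT assay, with a stated time of 72 h; on this read-out lower numbers stand for stronger inhibition and higher numbers for weaker inhibition:
- compound 1 `COc1cccc(CNCc2c(C(=O)O)n(Cc3ccc(F)cc3)c3ccccc23)c1`: > 50000 nM
- compound 2 `COc1ccc(Cn2c(C(=O)O)c(CNCc3cccc(O)c3)c3ccc(C(C)C)cc32)cc1`: 9270 nM
- compound 3 `COc1ccc(Cn2c(C(=O)O)c(CNCc3cccc(OC)c3)c3ccc(C(F)(F)F)cc32)cc1`: > 50000 nM

Compound 3 stands without a number: its value in this assay is a limit of the assay, not a measurement. Compound 1 likewise sits at a limit in this assay. Only compound 2, with isopropyl and a hydroxyl-bearing benzylamine, returns a number in this assay. Within the data shown here, no pair among the three differs in one place, so no measured step can be drawn, and the spread cannot be read from these values because the limit of > 50000 nM in this assay, at which 2 of the 3 values shown sit, leaves two of the three without a number.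

Compound 4 `COc1ccc(Cn2c(C(=O)O)c(CNCc3cccc(OC)c3)c3ccc(C)cc32)cc1` has not yet been measured in this assay. It differs from compound 3 by methyl in place of trifluoromethyl on an aromatic carbon. With compound 3 at a limit, any step from it can only be read downward or as none at all. Among the measured compounds shown here, the expectation is a modest gain rather than none, since the one numbered value in the set, that of compound 2, shows that a smaller alkyl on the shared core can give a measurable value; the estimated step is an at least 1.6-fold lower number from compound 3 to compound 4 (0.22 log units; that floor lies within the scatter). Compound 4 is accordingly expected to give about 30000 nM in this assay, within a range from 8000 nM to 100000 nM, with a fair chance that only a limit is again reported.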

Compound 4, half-maximal inhibitory concentration: 9830 nM
Estimate against measurement, compound 4: 3.1-fold (0.48 log units) above; the measured number falls inside the stated range.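

In this assay, among these compounds, the group on this aromatic carbon of the shared core can move the read-out by itself: methyl in place of trifluoromethyl gives an at least 5.0-fold lower number from compound 3 to compound 4 (0.70 log units; beyond the scatter), the first single-place step. Compound 4 thereby returns a number where compound 3 stands only at a limit, so this carbon now has a measured contrast rather than a lone limit value. The full size of the step remains unknown because one end of it is a limit and not a number: the limit of > 50000 nM in this assay, at which 2 of the 4 values shown sit.

A single pair cannot show whether the read-out follows the size of the group or some other feature of it, and ethyl or chlorine on this carbon would be needed to set methyl and trifluoromethyl within a wider trend. Compound 2 carries isopropyl on the same carbon but also differs from compound 4 in a second place, so isopropyl against methyl remains unresolved, as does whether the methyl gain would persist with other groups elsewhere on the shared core.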